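The compounds below may be only part of what the source reports. "The series", "measured", "known", "first", "only" and "open" are said of these compounds alone.

The series shares one core, carried in compound 2 `CCCCCCc1cc2c(=O)n(CCSc3nc(-c4cc(OC)c(OC)c(OC)c4)c(C#N)c(=O)[nH]3)cnc2s1` and in compound 1 `CCCCCc1cc2c(=O)n(CCCSc3nc(-c4cc(OC)c(OC)c(OC)c4)c(C#N)c(=O)[nH]3)cnc2s1`. Compound 1 reaches only the limit of an ADME assay on A549 cells (Homo sapiens) for inhibition, read by MTT assay (a higher number here means a weaker inhibitor of growth, a lower number a stronger inhibitor of growth), reported as > 100 ug/mL, which is a limit of the assay and not a number. In this assay, going by the values given here, compound 2 gives 96.8 ug/mL, the only number among the two values shown, while the other value sits at the limit of > 100 ug/mL in this assay, at which 1 of the 2 values shown sits. Compound 3 `CCCCCCCc1cc2c(=O)n(CCSc3nc(-c4cc(OC)c(OC)c(OC)c4)c(C#N)c(=O)[nH]3)cnc2s1` differs from compound 2 by methyl in place of hydrogen on a saturated chain carbon, six bonds along the chain from an aromatic carbon. Among the compounds with values here, no measured pair in this set isolates such a change, so nothing here fixes its size or direction, and the chain extension is expected to move the value by no more than the usual scatter. Compound 3 is therefore estimated at 95 ug/mL, with a range from 45 ug/mL to 200 ug/mL, which means an expected step of a 1.0-fold lower number from compound 2 to compound 3 (0.01 log units; within the scatter).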

Compound 3, concentration for 50% growth inhibition: 79.7 ug/mL
For compound 3 the middle estimate is 1.2-fold (0.08 log units) above the measured one; low and high end bracket the measured number.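

Going by these compounds alone, the first pair in this assay that differs in one place gives a 1.2-fold lower number from compound 2 to compound 3 (0.08 log units; within the scatter), for methyl in place of hydrogen on a saturated chain carbon, six bonds along the chain from an aromatic carbon. At this position the change therefore leaves the read-out within the scatter, and compound 2 and compound 3 cannot be placed in any order. Compound 1 remains a limit of the assay and not a number, and it differs from compound 2 in more than one place, so no step to it can be read: the limit of > 100 ug/mL in this assay, at which 1 of the 3 values shown sits.

A single step cannot show a trend along the chain. From the compounds shown here alone, whether a longer chain, or an amine or a carboxylic acid in place of this methyl, would move the value beyond the scatter remains open.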